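A few compounds are considered here, and "the series" means these few. Any claim that something is new, unique, unknown or untested is made for them only; others in the source may bear on it.

Compound 1 `Cc1nc2c(OCc3ccccc3)cccn2c1N` is the strongest of the three compounds measured in a functional assay on the whole organism with Canis familiaris (Canis lupus familiaris) as the target, at a dose of 8 mg/kg by the oral route; a higher number here means a stronger effect of the compound at the dose given, a lower number a weaker effect: compound 1 gives 96%. Compound 2 `Cc1nc2c(OCc3ccsc3)cccn2c1N` gives 88% in this assay, and compound 3 `Cc1cc(OCc2ccccc2)c2nc(C)c(N)n2c1` gives 50%. The two steps recorded so far, a number 8 percentage points lower from compound 1 to compound 2 (within the scatter) and a number 46 percentage points lower from compound 1 to compound 3 (beyond the scatter), concern the benzyl-type group and an aromatic carbon of the core, not the nitrogen that changes here. Compound 4 `CCCNc1c(C)nc2c(OCc3ccccc3)cccn12` differs from compound 1 by propyl in place of hydrogen on a nitrogen on an aromatic ring. Among the compounds with values here, no measured step bears directly on this change, so the estimate leans on compound 1 alone and allows for a drop. Compound 4 is therefore expected to give 70% in this assay, within 35% to 95%, which means an estimated step of a number 26 percentage points lower from compound 1 to compound 4 (beyond the scatter).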

Compound 4, a percentage reported as inhibition, in the whole organism at one dose (the size of the read-out at that dose, not a potency): 68%
Compound 4: middle estimate off by 2 percentage points, on the high side; the range from low to high includes it.
By their numbers in this assay, from the lowest: compound 3; then compound 4; then compounds 2 and 1 (each within the scatter of the next).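

The change from amino to propylamino gives a number 28 percentage points lower from compound 1 to compound 4 (beyond the scatter) in this assay. Within the data shown here, this is the first measured change on this nitrogen, and it shows that the hydrogen can be replaced with an effect remaining, though at a cost: compound 4 still gives 68% at the one dose tested. The compounds shown leave open whether a methyl or ethyl group, a longer chain, or an acetyl group on this nitrogen would stay closer to compound 1 or fall further. Nothing in the data given explains the size of this step.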